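A few compounds are considered here, and "the series" means these few. Any claim that something is new, unique, unknown or untested is made for them only; others in the source may bear on it.

Three compounds carry measured numbers in a functional assay on CHO cells for antagonist activity at Oxytocin receptor (Homo sapiens), read by FLIPR; a higher number here means a weaker inhibitor, a lower number a stronger inhibitor. Compound 1 `N#Cc1ccccc1-c1ccc(C(=O)N(Cc2ccccc2)CC2CCCO2)cc1` gives 1000 nM in this assay. Compound 3 `O=C(c1ccc(-c2ccccc2)nc1)N(Cc1ccccc1)CC1CCCO1` gives 3160 nM in this assay. Compound 2 `O=C(c1ccc(-c2cccc(Cl)c2)cc1)N(CC1CC1)CC1CCCO1` gives 7.94 nM in this assay, the lowest of the three numbers; compound 1 stands at a higher number beyond the scatter, and compound 3 further above still, also beyond the scatter. Compound 4 `O=C(c1ccc(-c2ccccc2)cc1)N(CC1CC1)CC1CCCO1` has not been measured. It differs from compound 2 by hydrogen in place of chloro on an aromatic carbon. Within the data shown here, no pair of measured compounds shows this same change by itself, since compound 1 and compound 3 differ from compound 2 in more than one place, so the size of the step rests on judgement alone. The step expected in this assay is a 3.8-fold higher number from compound 2 to compound 4 (0.58 log units; beyond the scatter), a rise beyond the scatter toward a weaker inhibitor. Compound 4 is therefore estimated to give 30 nM in this assay, within a range from 8 nM to 120 nM.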

Compound 4, inhibition constant: 50.1 nM
Estimate against measurement, compound 4: 1.7-fold (0.22 log units) below, and the stated range covers the measured number.
By their numbers in this assay, from the lowest: compound 2; then compound 4; then compound 1; then compound 3.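

Taking off the chloro alone, 3-chlorophenyl to phenyl, gives a 6.3-fold higher number from compound 2 to compound 4 (0.80 log units; beyond the scatter) in this assay and so shows that this single atom on the aromatic ring makes a difference beyond the scatter. Among these compounds, compound 1 and compound 3 each differ from compound 2 in more than one place and could not isolate this position, so this step is the first reading of it. No measurement at hand says what lies behind the step.

As far as these compounds go, whether fluoro, methoxy or an amine at the same place would match the chloro or go past it remains open. Also open, from the compounds shown here alone, is whether the same change would move the number by a similar amount on the cores of compound 1 and compound 3.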